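A few compounds are considered here, and "the series" means these few. Any claim that something is new, unique, unknown or untested is made for them only; others in the source may bear on it.

Compound 1 `Fc1ccccc1C1Cc2nccn2C1` gives "not determined" (no result reported)
Compound 2 `NC(=O)c1ccccc1C1Cc2nccn2C1` gives "not determined" (no result reported)
Compound 3 `COc1ccccc1C1Cc2nccn2C1` gives 37 mL.min-1.g-1

The three compounds share one core, and the measured picture in an in vitro ADME assay on microsomes from liver (Homo sapiens) for metabolic stability (on this read-out higher numbers stand for fast clearance and lower numbers for slow clearance), is thin. Going by the values given here, compound 3 holds the only number (37 mL.min-1.g-1). Among the compounds with values here, compound 1 and compound 2 have no reported result, so compound 3 cannot be ranked against anything, and no step between measured compounds is available as a guide.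

Compound 4 `Clc1ccccc1C1Cc2nccn2C1` has not yet been measured. It has chloro in place of methoxy on an aromatic carbon, ortho to a group of 8 heavy atoms (chloro in place of methoxy on an aromatic carbon). With nothing to go on except the value of compound 3 (37 mL.min-1.g-1), no shift beyond the usual scatter is expected in this assay, and the data favour no direction. The estimated 1.2-fold lower number from compound 3 to compound 4 (0.09 log units; within the scatter) therefore stays within that scatter. Compound 4 is estimated at 30 mL.min-1.g-1 (expected range 14 mL.min-1.g-1 to 65 mL.min-1.g-1).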

Compound 4, intrinsic clearance in microsomes: 18 mL.min-1.g-1
The estimate for compound 4 lay 1.7-fold (0.22 log units) above the measured number, within the range that was stated.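

In this assay, chloro in place of methoxy on an aromatic carbon, ortho to a group of 8 heavy atoms, gives a 2.1-fold lower number from compound 3 to compound 4 (0.31 log units; beyond the scatter), so this position does respond to a change of substituent, and the single step shown lies beyond the usual scatter. Steps to compound 1 and compound 2 cannot be read, since neither compound carries a number. Nothing shown here explains why the number drops with this exchange.

The compounds shown leave open whether this one step reflects a wider trend at this position or belongs to the exchange of these two groups alone. They also leave open how an amine, a nitrile or a longer chain such as ethoxy would read at the same place on the ring.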